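A few compounds are considered here, and "the series" means these few. Any claim that something is new, unique, unknown or untested is made for them only; others in the source may bear on it.

Measured so far in a functional assay on K562 cells (Homo sapiens) for antiproliferative activity, with a stated time of 72 h; on this read-out lower numbers stand for stronger inhibition and higher numbers for weaker inhibition:
- compound 1 `OC[C@H]1O[C@@H](n2cnc3c(NCc4ccccc4F)ncnc32)[C@H](O)[C@@H]1O`: 33200 nM
- compound 2 `OC[C@H]1O[C@@H](n2cnc3c(NCc4cccc(F)c4)ncnc32)[C@H](O)[C@@H]1O`: 7600 nM

Of these two numbers, the lower belongs to compound 2, at 7600 nM. Compound 3 `OC[C@H]1O[C@@H](n2cnc3c(NCc4ccc(F)cc4)ncnc32)[C@H](O)[C@@H]1O` has not yet been measured. It keeps the shared core and differs from compound 2 in a single group: 4-fluorophenyl in place of 3-fluorophenyl on a saturated chain carbon bound to a nitrogen on an aromatic ring. The two have the same atoms, joined differently.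

Among the compounds with values here, only one measured step bears on this change, and it is of the same kind and at the same place. That step, a 4.4-fold lower number from compound 1 to compound 2 (0.64 log units; beyond the scatter), is modest and replaces 2-fluorophenyl with 3-fluorophenyl. It shows that such a swap can move the number beyond the scatter, but it does not show which way a move to 4-fluorophenyl will go. Within the data shown here, no compound with that group has a measured value. A step of similar modest size is therefore expected, leaning slightly towards a higher number, with the direction uncertain. The expected change is a 1.4-fold higher number from compound 2 to compound 3 (0.16 log units; within the scatter). For compound 3 the estimated value is 11000 nM, within an expected range of 3500 nM to 30000 nM.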

Compound 3, half-maximal inhibitory concentration: 2700 nM
Estimate against measurement, compound 3: 4.1-fold (0.61 log units) above, outside the stated range (below it).
By their numbers in this assay, from the lowest: compound 3; then compound 2; then compound 1.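

In this assay, replacing 3-fluorophenyl with 4-fluorophenyl on a saturated chain carbon bound to a nitrogen on an aromatic ring gives a 2.8-fold lower number from compound 2 to compound 3 (0.45 log units; beyond the scatter). This step runs in the same direction as the earlier one, so among these three compounds the numbers fall in the order 2-fluorophenyl, 3-fluorophenyl, 4-fluorophenyl, and the whole series spans a 12-fold lower number from compound 1 to compound 3 (1.09 log units; beyond the scatter), which shows that the choice among isomeric fluorophenyl groups alone can produce a large step at this place. No measurement offered here accounts for this order.

From the compounds shown here alone, what a 4-chlorophenyl, a 4-methoxyphenyl or an unsubstituted phenyl group would give at this place remains open, as does whether the order of the three fluorophenyl groups would survive a longer chain in place of the benzyl link to the nitrogen. Whether the same order holds in any read-out other than this assay is also left open by the compounds shown.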